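The compounds below may be only part of what the source reports. "The series", "measured", "known", "first", "only" and "open" are said of these compounds alone.

Compound 1 `O=C(O)c1cc(Cl)cc2cc(CNC(=O)c3cnn4cccnc34)oc12`: 100%
Compound 2 `C[C@@H](OC(=O)c1cc(Cl)cc2cc(CNC(=O)c3cnn4cccnc34)oc12)C(F)(F)F`: 1.4%

Of these two numbers, compound 2 holds the lower, at 1.4%. Compound 3 `O=C(NCc1cc2cc(Cl)cc(-c3nn[nH]n3)c2o1)c1cnn2cccnc12` comes from compound 2 through 2H-tetrazol-5-yl in place of (1-(trifluoromethyl)ethoxy)carbonyl on an aromatic carbon. Within the data shown here, one measured step bears on this change: a number 98.6 percentage points lower from compound 1 to compound 2 (beyond the scatter), a large fall beyond the scatter on adding the 1-(trifluoromethyl)ethyl group. Among the measured compounds shown here, compound 3 no longer carries that group, although no compound with 2H-tetrazol-5-yl has been measured to show how it behaves. A large rise in an ADME assay on microsomes from liver (Homo sapiens) for metabolic stability, with a stated time of 10 min, tested at 0.5 uM (a lower number here means that less of the compound is left, a higher number that more of the compound is left), is therefore expected, towards compound 1 at 100%. The expected change is a number 86.6 percentage points higher from compound 2 to compound 3 (beyond the scatter). For compound 3, the estimated value is 88%, with an expected range of 65% to 100%.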

Compound 3, percent of the compound remaining: 96%
Estimate against measurement, compound 3: 8 percentage points below; low and high end bracket the measured number.
By their numbers in this assay, from the lowest: compound 2; then compounds 3 and 1 (each within the scatter of the next).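

In this assay, 2H-tetrazol-5-yl in place of (1-(trifluoromethyl)ethoxy)carbonyl gives a number 94.6 percentage points higher from compound 2 to compound 3 (beyond the scatter), so the low number seen with that group does not carry over once it leaves this aromatic carbon. With 2H-tetrazol-5-yl in place of carboxy, the read-out shows a number 4 percentage points lower from compound 1 to compound 3 (within the scatter), so the two groups cannot be told apart at this position in this assay. No evidence is available to explain either step.

The compounds shown leave open whether a simple methyl ester at this position would also give a low number, or whether that belongs to the (1-(trifluoromethyl)ethoxy)carbonyl group alone. They also leave open how a primary amide or an amine on the same aromatic carbon would read in this assay.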